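Adding Two Methyl Groups to a Potent Sulfonamide

A few compounds are considered here, and "the series" means these few. Any claim that something is new, unique, unknown or untested is made for them only; others in the source may bear on it.

Three compounds share one core and differ only in the length of a carbon chain: compound 1 (`O=C(/C=C/c1cccnc1)NCCCc1cccc(S(=O)(=O)Nc2ccccc2)c1`), compound 2 (`O=C(/C=C/c1cccnc1)NCCCCCc1cccc(S(=O)(=O)Nc2ccccc2)c1`) and compound 3 (`O=C(/C=C/c1cccnc1)NCCCCCCc1cccc(S(=O)(=O)Nc2ccccc2)c1`). In a functional assay on Huh-7 cells (Homo sapiens) for inhibition, read by CCK-8 assay, with a stated time of 72 h (a higher number here means a weaker inhibitor, a lower number a stronger inhibitor), compound 1 gives 384 nM. In the same test, compound 2 gives 41.1 nM, and compound 3 gives 2.82 nM. Compound 3 therefore has the lowest number of the three, and it stands clearly apart from the other two, well beyond the usual scatter. Among these three compounds, the longer chain goes with the lower number, and none goes against that trend.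

The next compound keeps the chain of compound 3 and changes the other end of the molecule. Compound 4 (`Cc1ccc(C)c(NS(=O)(=O)c2cccc(CCCCCCNC(=O)/C=C/c3cccnc3)c2)c1`) carries 2,5-dimethylphenyl in place of phenyl on a sulfonamide nitrogen. Among the compounds with values here, none of the measured compounds varies this group, so the data give no direct guide to the effect of this change. The expectation is therefore cautious: no step beyond the scatter in this assay, with a slight rise in the number as the likeliest outcome. The estimated change is a 1.6-fold higher number from compound 3 to compound 4 (0.20 log units; within the scatter). For compound 4, the estimated value is 4.5 nM, within an expected range of 0.9 nM to 22 nM.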

Compound 4, half-maximal inhibitory concentration: 2.58 nM
Compound 4: the middle estimate sits 1.7-fold (0.24 log units) above what was measured; the range from low to high includes it.
By their numbers in this assay, from the lowest: compounds 4 and 3 (each within the scatter of the next); then compound 2; then compound 1.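

Placing 2,5-dimethylphenyl in place of phenyl on a sulfonamide nitrogen gives a 1.1-fold lower number from compound 3 to compound 4 (0.04 log units; within the scatter) in this assay, so the two compounds cannot be told apart in this test. Within the data shown here, the earlier compounds varied only the carbon chain and showed how strongly the number followed its length; this pair is the first look at the other end of the molecule, and it shows that this position can carry a larger carbon-only ring group while the number stays as low as that of compound 3. Nothing in the data shown explains why the added methyl groups leave the number in place.

A single pair cannot show how far this tolerance extends, since a group of a different kind on that ring, such as a carboxylic acid, an amine or a chlorine atom, might give quite a different number. It also leaves open whether either methyl group alone would read like compound 4, and whether a chain longer than that of compound 3 would lower the number any further.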